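The source may report more compounds than this note shows. Statements on the series, on what has been measured and on what is new or still open speak of the compounds shown alone.

Among the measured compounds shown here, in a functional assay on a cell-free system (plasma, Homo sapiens) for inhibition, with Plasma (Rattus norvegicus) as the target (a higher number here means a weaker inhibitor, a lower number a stronger inhibitor), compound 1 (`O=C(O)CCNC(=O)c1cccc(C(=O)Nc2ccc3c(c2)CNCC3)c1`) gives 78 nM and compound 2 (`O=C(O)CC(NC(=O)c1cccc(C(=O)Nc2ccc3c(c2)CNCC3)c1)c1ccccc1`) gives 25 nM as the lower of the two numbers so far. Compound 3 (`COc1ccc(C(CC(=O)O)NC(=O)c2cccc(C(=O)Nc3ccc4c(c3)CNCC4)c2)cc1`) differs from compound 2 in a single place, described as methoxy in place of hydrogen on an aromatic carbon in the counted terms. This is methoxy in place of hydrogen on an aromatic carbon, so that phenyl becomes 4-methoxyphenyl. For the measured compounds named here, only one measured step bears on this change: a 3.1-fold lower number from compound 1 to compound 2 (0.49 log units; beyond the scatter) is a modest step that introduced the phenyl itself. Going by the values given here, that step shows that the number moved when the phenyl was added, but no measured compound carries anything on that phenyl, so the data offer no direct precedent for the methoxy. From the compounds shown here alone, without such a precedent, only a small movement is expected, and the direction remains open. The expected outcome is a 1.1-fold lower number from compound 2 to compound 3 (0.06 log units; within the scatter) as a best guess, with a real step in either direction still possible. Compound 3 is estimated at 22 nM in this assay (expected range 9 nM to 55 nM).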

Compound 3, half-maximal inhibitory concentration: 17 nM
Compound 3: middle estimate off by 1.3-fold (0.11 log units), on the high side, and the stated range covers the measured number.
By their numbers in this assay, from the lowest: compounds 3 and 2 (each within the scatter of the next); then compound 1.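

In this assay, among the compounds shown here, methoxy on an aromatic carbon of the phenyl gives a 1.5-fold lower number from compound 2 to compound 3 (0.17 log units; within the scatter), so this carbon, para to a large group, carries the methoxy and the number stays within the scatter of that of compound 2, which no earlier compound could show. The larger group in place of hydrogen on the saturated chain carbon also keeps the gain over the unbranched chain, with 4-methoxyphenyl giving a 4.6-fold lower number from compound 1 to compound 3 (0.66 log units; beyond the scatter) beyond the scatter, just as the plain phenyl gave a 3.1-fold lower number from compound 1 to compound 2 (0.49 log units; beyond the scatter) beyond the scatter. No measurement at hand speaks to the cause of any of these steps.

For the compounds shown here, with only a single group on the phenyl, it remains open whether a hydroxyl, a chlorine or a nitrile on that same aromatic carbon would give a step beyond the scatter, or whether another place on the ring would behave as this one does. The compounds shown also leave open how a primary amide in place of the carboxylic acid, or a longer chain between that acid and the amide nitrogen, would read in this assay when combined with the 4-methoxyphenyl.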